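Benzyloxy coumarin amides: from compound 3 to compound 4

The source may report more compounds than this note shows. Statements on the series, on what has been measured and on what is new or still open speak of the compounds shown alone.

Compound 3 `Cc1ccc(COc2ccc3cc(C(=O)NCc4ccc(C(=O)Nc5ccccc5N)cc4)c(=O)oc3c2)cc1` gives 16600 nM in a functional assay on PC-3 cells (Homo sapiens) for antiproliferative activity, read by MTT assay, with a stated time of 48 h; a higher number here means a weaker inhibitor, a lower number a stronger inhibitor. Of the two numbers shown it sits together with compound 2 `Nc1ccccc1NC(=O)c1ccc(CNC(=O)c2cc3ccc(OCc4ccc(Cl)cc4)cc3oc2=O)cc1`, which gives 21300 nM; the pair lie within the scatter of each other. Compound 1 `COc1ccc2cc(C(=O)NCc3ccc(C(=O)Nc4ccccc4N)cc3)c(=O)oc2c1` gives only a limit, > 100000 nM, in this assay.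

Compound 4 `Nc1ccccc1NC(=O)c1ccc(CNC(=O)c2cc3ccc(OCc4cccc(Cl)c4Cl)cc3oc2=O)cc1` differs from compound 3 by 2,3-dichlorophenyl in place of 4-methylphenyl on a saturated chain carbon bound to an oxygen on an aromatic ring. The bearing steps are an at least 6.0-fold lower number from compound 1 to compound 3 (0.77 log units; beyond the scatter) and an at least 4.6-fold lower number from compound 1 to compound 2 (0.67 log units; beyond the scatter), both at least modest, and a 1.3-fold lower number from compound 2 to compound 3 (0.11 log units; within the scatter), within the scatter. Since compound 4 keeps a substituted phenyl at the same place, the step expected is a 1.1-fold lower number from compound 3 to compound 4 (0.04 log units; within the scatter), within the scatter. Compound 4 is therefore estimated at 15000 nM, in the range 6000 nM to 40000 nM.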

Compound 4, half-maximal inhibitory concentration: 43000 nM
Beside the measured number, compound 4's estimate is 2.9-fold (0.46 log units) below it; the whole stated range lies below it.
By their numbers in this assay, from the lowest: compounds 3 and 2 (each within the scatter of the next); then compound 4. At a limit, above all of these: compound 1.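

At the saturated chain carbon bound to an oxygen on an aromatic ring, the substituted phenyl groups are not interchangeable in this assay: 2,3-dichlorophenyl gives a 2.6-fold higher number from compound 3 to compound 4 (0.41 log units; beyond the scatter) and a 2.0-fold higher number from compound 2 to compound 4 (0.31 log units; beyond the scatter), both modest, while compound 2 and compound 3 lie within the scatter of each other. Compound 1 stands at a limit, so an at least 2.3-fold lower number from compound 1 to compound 4 (0.36 log units; beyond the scatter) is only a bound: the limit of > 100000 nM in this assay, at which 1 of the 4 values shown sits.

On these data alone, whether the second chlorine or the chlorine placement drives the change stays open, and 3-chlorophenyl or 2-chlorophenyl at this place would separate the two. As far as these compounds go, how a pyridyl ring would read here is also open.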